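Ethoxy to Methyl on the Side Chain of Compound 2

The compounds below may be only part of what the source reports. "The series", "measured", "known", "first", "only" and "open" are said of these compounds alone.

Measured so far in an ADME assay on microsomes from liver (Rattus norvegicus) for metabolic stability, with a stated time of 10 min, tested at 0.5 uM; on this read-out lower numbers stand for a less stable compound and higher numbers for a more stable compound:
- compound 1, `CCC(Nc1nnc(-c2ccc(OC)cc2)o1)[C@H]1CC[C@@H](c2ccnc3ccc(F)cc32)CC1`: 45%
- compound 2, `CCOCC(Nc1nnc(-c2ccc(OC)cc2)o1)[C@H]1CC[C@@H](c2ccnc3ccc(C(F)(F)F)cc32)CC1`: 53%
- compound 3, `COc1ccc(Nc2nnc([C@H](C)[C@H]3CC[C@@H](c4ccnc5ccc(F)cc54)CC3)o2)cc1`: 0.4%

Among these three numbers compound 2 has the highest value in this assay. Its nearest neighbour is compound 1, whose value lies within the usual scatter of compound 2, so no order between the two can be read from the data. Compound 3 lies far beyond the scatter, with almost nothing of the compound left at the end of the test.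

The next compound, compound 4, `CCC(Nc1nnc(-c2ccc(OC)cc2)o1)[C@H]1CC[C@@H](c2ccnc3ccc(C(F)(F)F)cc32)CC1`, has not yet been measured. Its structure is set apart from compound 2 by one change: methyl in place of ethoxy on a saturated chain carbon, two bonds along the chain from a nitrogen on an aromatic ring and a saturated ring carbon. The same change, cut one bond further out, reads as ethoxymethyl to ethyl.

Going by the values given here, no step between two measured compounds shows this exact change. Still, compound 1 already carries the ethyl chain, and in this assay compound 1 gives 45%, a number within the scatter of compound 2. On that basis the step from compound 2 to compound 4 is expected to be small, with no direction that stands out beyond the scatter: a number 5 percentage points lower from compound 2 to compound 4 (within the scatter). For compound 4 the estimated value in this assay is 48%, with a range from 30% to 65%.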

Compound 4, percent of the compound remaining: 100%
For compound 4 the middle estimate is 52 percentage points below the measured one; the whole stated range lies below it.
By their numbers in this assay, from the lowest: compound 3; then compounds 1 and 2 (each within the scatter of the next); then compound 4.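

In this assay there is a number 47 percentage points higher from compound 2 to compound 4 (beyond the scatter) with a single change, methyl in place of ethoxy on a saturated chain carbon, two bonds along the chain from a nitrogen on an aromatic ring and a saturated ring carbon, so the read-out clearly responds to what sits at this place on the side chain. There is also a number 55 percentage points higher from compound 1 to compound 4 (beyond the scatter) with trifluoromethyl in place of fluoro on an aromatic carbon, so the same side chain can give very different numbers depending on that group, something compound 1 and compound 2 could not show, since they differ from each other in two places at once. Nothing measured here gives a reason for either step.

Still open, as far as these compounds go, is whether a longer chain such as propyl, a methoxymethyl chain or an amine at this place would keep the high number seen for compound 4. Also open, from the compounds shown here alone, is how the ethyl chain and the ethoxymethyl chain compare when fluoro stands on the aromatic carbon, which would show whether the two changes act separately or only in combination.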